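Benzyl in Place of Aryl on a Shared Quinoline Core

The source may hold more compounds than are shown below. What is called first, only, known or untested is meant among the compounds shown, and "the series" means these compounds.

Measured so far, in an ADME assay on HepG2 cells (Homo sapiens) for cytotoxicity, read by luminescence, CellTiter-Glo and ATP content, with a stated time of 72 h; on this read-out higher numbers stand for an effect only at larger amounts of compound and lower numbers for an effect already at smaller amounts:
compound 1, `Fc1ccc(-c2ccc3c(NCCCNCc4ccco4)ccnc3c2)cc1`: 7760 nM
compound 2, `COc1ccc(F)cc1CNCCCNc1ccnc2cc(Cc3ccc(F)cc3)ccc12`: 3530 nM
compound 3, `COc1ccc(-c2ccc3c(NCCCNCc4ccco4)ccnc3c2)cc1`: 6000 nM

Compound 3 stands second highest of the three numbers. Its nearest neighbour is compound 1, whose value of 7760 nM sits within the scatter of compound 3, and the step of a 1.3-fold lower number from compound 1 to compound 3 (0.11 log units; within the scatter) is the only one that joins two measured compounds differing in a single place. Compound 2, with 3530 nM, lies furthest from compound 3, yet still within the scatter.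

The next compound, compound 4 `Fc1ccc(Cc2ccc3c(NCCCNCc4ccco4)ccnc3c2)cc1`, arises from compound 3 through (4-fluorobenzyl in place of 4-methoxyphenyl on an aromatic carbon). For the measured compounds named here, no measured step covers this exact exchange. The step of a 1.3-fold lower number from compound 1 to compound 3 (0.11 log units; within the scatter) bears on it only in part, since it swaps methoxy for fluoro and was within the scatter. Compound 2 carries the same 4-fluorobenzyl at the same place with a different side chain and gives 3530 nM, a number within the scatter of compound 3. On this basis compound 4 is expected to show a step of a 1.2-fold lower number from compound 3 to compound 4 (0.08 log units; within the scatter), that is, no change beyond the scatter. The estimate for compound 4 in this assay is 5000 nM, with a range from 2000 nM to 12000 nM.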

Compound 4, half-maximal effective concentration: 5600 nM
Estimate against measurement, compound 4: 1.1-fold (0.05 log units) below, within the range that was stated.
By their numbers in this assay, from the lowest: compounds 2, 4, 3 and 1 (each within the scatter of the next, the first and the last beyond it).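

In this assay, 4-fluorobenzyl on this aromatic carbon stays within the scatter whether it replaces 4-methoxyphenyl (a 1.1-fold lower number from compound 3 to compound 4 (0.03 log units; within the scatter)) or 4-fluorophenyl (a 1.4-fold lower number from compound 1 to compound 4 (0.14 log units; within the scatter)), and the second exchange keeps the fluoro group on the ring, so it sets the benzyl form directly against the aryl form. For the compounds shown here, with 4-fluorobenzyl held in place, the first measured step at the far end of the saturated chain, where furan-2-yl takes the place of 5-fluoro-2-methoxyphenyl, also stays within the scatter (a 1.6-fold higher number from compound 2 to compound 4 (0.20 log units; within the scatter)), so neither exchange separates these compounds on this read-out. No measurement is at hand that could account for these small steps.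

The compounds shown cover only aromatic and carbon-linked groups of similar size at these two places, so it remains open whether a carboxylic acid or an amine on this aromatic carbon would carry the number beyond the scatter. On these data alone, it is equally open whether a longer chain in place of the present saturated chain would do so, with either 4-fluorobenzyl or 4-fluorophenyl on the shared core.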